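The source may hold more compounds than are shown below. What is called first, only, known or untested is meant among the compounds shown, and "the series" means these compounds.

Compound 1, `C[C@@H](Cn1ccc(-c2ccc(C#N)c(Cl)c2)n1)NC(=O)c1ccccc1`: in an ADME assay on PC-3 cells (Homo sapiens) for cytotoxicity, read by CCK-8 assay, with a stated time of 6 days (a lower number here means a stronger inhibitor, a higher number a weaker inhibitor), compound 1 gives > 30000 nM, a limit of the assay rather than a number.
Compound 2, `CC(Cn1ccc(-c2ccc(C#N)c(Cl)c2)n1)C(=O)Nc1cc[nH]n1`: compound 2 gives > 30000 nM, again a limit.
Compound 3, `CC(Cn1ccc(-c2ccc(C#N)c(Cl)c2)n1)C(=O)Nc1cccc(C(C)O)c1`: compound 3 gives > 30000 nM, also a limit.

For the measured compounds named here, compound 3 therefore stands at the limit, and no number places it relative to the other two; every value measured so far sits at the limit of > 30000 nM in this assay, at which 3 of the 3 values shown sit. Going by the values given here, the one measured step on the amide side, a step that the two limits leave unreadable from compound 2 to compound 3, cannot be read, both of its ends sitting at the limit of > 30000 nM in this assay, at which 3 of the 3 values shown sit.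

Compound 4, `CC(=O)c1cccc(NC(=O)C(C)Cn2ccc(-c3ccc(C#N)c(Cl)c3)n2)c1`, differs from compound 3 by acetyl in place of 1-hydroxyethyl on an aromatic carbon. Among the compounds with values here, no measured step touches this position, and no measured step in this assay has given a readable size at all, so there is nothing to set a direction from. Compound 4 is expected to remain at the limit, the step of a number no higher from compound 3 to compound 4 (the limit leaves the size open) being expected as none beyond the scatter. The estimate for compound 4 in this assay is 30000 nM, with a range from 10000 nM to 100000 nM, most likely reported again only as a limit.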

Compound 4, half-maximal inhibitory concentration: > 30000 nM
Compound 4 ended at the assay's limit (the forecaster's own chance of this, stated with the estimate: 85%); the middle value sits exactly at the limit.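

No step among compound 2, compound 3 and compound 4 can be read, because both ends of each step sit at the same limit: the limit of > 30000 nM in this assay, at which 4 of the 4 values shown sit.

The compounds shown leave open whether any change to the amide side or the shared core gives a readable half-maximal inhibitory concentration.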